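Swapping the Alkenyl Acyl Group for Methoxymethyl

This account rests on a few compounds, and the source may have more. Where it says the series, first, only, none or still open, it means among the compounds named here.

Of the compounds shown here, three sharing one core have been tested in a functional assay on HCT-116 cells (Homo sapiens) for inhibition, read by MTT assay, with a stated time of 48 h; a higher number here means a weaker inhibitor, a lower number a stronger inhibitor. Compound 1 `CCC/C=C/C(=O)N(Cc1ccc(OC)c(O)c1)c1cc(OC)c(OC)c(OC)c1` gives 95 nM, the lowest of the three numbers and therefore the strongest inhibitor of this set. Its nearest neighbour is compound 3 `C/C=C/C(=O)N(Cc1ccc(OC)c(Cl)c1)c1cc(OC)c(OC)c(OC)c1`, which in this assay gives 1420 nM, a gap that lies beyond the usual scatter. Compound 2 `COc1cc(NCc2cccc(O)c2)cc(OC)c1OC`, which carries no acyl group on its nitrogen at all, gives 67700 nM in this assay, the highest number here and far beyond the scatter from compound 1.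

The next compound, compound 4 `COCC(=O)N(Cc1ccc(OC)c(O)c1)c1cc(OC)c(OC)c(OC)c1`, has not been measured. It differs from compound 1 in one place (methoxymethyl in place of pent-1-en-1-yl on a carbonyl carbon). The acyl group on the amide-type nitrogen is thus shortened and given an oxygen in place of its double bond, while the rest of compound 1 is kept.

Going by the values given here, no step between measured compounds isolates this change, so the direction can only be read from how much the acyl group seems to matter: compound 2, without one, gives 67700 nM, and compound 3, with a shorter alkenyl acyl group, gives 1420 nM. On that basis compound 4 is expected to be a weaker inhibitor than compound 1, with a step of a 16-fold higher number from compound 1 to compound 4 (1.20 log units; beyond the scatter) that lies beyond the scatter, and an estimated value in this assay of 1500 nM, within a range from 300 nM to 8000 nM.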

Compound 4, half-maximal inhibitory concentration: 230 nM
For compound 4 the middle estimate is 6.5-fold (0.81 log units) above the measured one; the whole stated range lies above it.
By their numbers in this assay, from the lowest: compound 1; then compound 4; then compound 3; then compound 2.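

In this assay, putting methoxymethyl in place of pent-1-en-1-yl on the carbonyl carbon weakens inhibition only modestly (a 2.4-fold higher number from compound 1 to compound 4 (0.38 log units; beyond the scatter)). Going by these compounds alone, this pair gives the first direct reading at this position, and compound 4 still gives 230 nM even though the group on the carbonyl carbon goes from five heavy atoms to three, loses its double bond and gains a hydrogen-bond acceptor. So, in this one pair, the long alkenyl chain of compound 1 can be replaced at a modest cost, but several features change together and the step cannot be divided among them. No measurement shown here explains the size of this step.

Going by these compounds, it remains open whether the oxygen of methoxymethyl helps, harms or makes no difference, which a plain propyl group on the same carbonyl carbon could help to separate. On these data alone, how a longer ether chain, an amine-bearing chain or a carboxylic acid would behave at this position also remains unknown.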